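The source may hold more compounds than are shown below. What is called first, only, known or untested is meant among the compounds shown, and "the series" means these compounds.

Two compounds of the series carry values in an ADME assay on BV-2 cells (Mus musculus) for cytotoxicity, read by MTT assay, with a stated time of 48 h, tested at 15 uM; on this read-out lower numbers stand for a stronger effect and higher numbers for a weaker effect at the one concentration tested. Going by the values given here, compound 1 `O=C1COCCN1c1ccc(/N=C\c2c[nH]c3ccccc23)cc1` gives 100% in this assay, and compound 2 `Cc1ccc(S(=O)(=O)n2cc(/C=N\c3ccc(N4CCOCC4=O)cc3)c3ccccc32)cc1` gives 71% in this assay, the lowest of the two numbers; the step of a number 29 percentage points lower from compound 1 to compound 2 (beyond the scatter) is the only measured step in the set. Compound 3 `O=C1COCCN1c1ccc(/N=C\c2cn(C(=O)c3ccccc3)c3ccccc23)cc1` differs from compound 2 by benzoyl in place of (4-methylphenyl)sulfonyl on an aromatic nitrogen. Among the compounds with values here, the one measured step bears on the same aromatic nitrogen, yet it exchanges hydrogen for a substituent rather than one substituent for another, so it gives only a loose guide. No step beyond the scatter is expected: a number 7 percentage points higher from compound 2 to compound 3 (within the scatter). Compound 3 is therefore estimated at 78% in this assay, within 60% to 96%.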

Compound 3, a percentage reported as activity, at one concentration (the size of the read-out at that concentration, not a potency): 86.6%
Beside the measured number, compound 3's estimate is 8.6 percentage points below it; the range from low to high includes it.
By their numbers in this assay, from the lowest: compound 2; then compound 3; then compound 1.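

On the aromatic nitrogen, the identity of the substituent matters in this assay, not only its presence: a number 15.6 percentage points higher from compound 2 to compound 3 (beyond the scatter) with benzoyl in place of (4-methylphenyl)sulfonyl. Benzoyl also stands apart from hydrogen, a number 13.4 percentage points lower from compound 1 to compound 3 (beyond the scatter), so both substituents shown read lower than hydrogen, with the sulfonyl group lowest. Nothing available accounts for the difference between the two groups. Open, from the compounds shown here alone, is where a simple methyl group, a longer alkyl chain or a chain ending in an amine or a carboxylic acid would fall on this nitrogen.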